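This account rests on a few compounds, and the source may have more. Where it says the series, first, only, none or still open, it means among the compounds named here.

Measured in a functional assay on RAW264.7 cells (Mus musculus) for inhibition; a higher number here means a weaker inhibitor, a lower number a stronger inhibitor:
compound 1, `O=C1/C(=C/c2ccccc2Cl)CCc2cc(O)ccc21`, 1910 nM
compound 2, `O=C1/C(=C/c2ccccc2Br)CCc2cc(O)ccc21`, 1070 nM
compound 3, `O=C1/C(=C/c2ccccc2Cl)CCc2ccc(O)cc21`, 270 nM

Compound 1 and compound 2 share one core. Compound 3 is built from the same atoms joined differently, and how its core differs from the core of compound 1 is not broken down here. The number for compound 3 is lower than the numbers for compound 1 and compound 2 by gaps that go beyond the usual scatter, so of the three it is the strongest inhibitor in this assay.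

Between compound 1 and compound 2 a single change is made: bromo in place of chloro on an aromatic carbon. This gave a 1.8-fold lower number from compound 1 to compound 2 (0.25 log units; within the scatter), a step that stays within the scatter.

Compound 4, `O=C1/C(=C/c2ccccc2Br)CCc2ccc(O)cc21`, has not yet been measured. It arises from compound 3 by the same change, (bromo in place of chloro on an aromatic carbon), at a place described in exactly the same words. Because the earlier step of a 1.8-fold lower number from compound 1 to compound 2 (0.25 log units; within the scatter) stayed within the scatter, only a small shift is expected here too. Compound 4 is therefore expected to show a 1.6-fold lower number from compound 3 to compound 4 (0.20 log units; within the scatter). Compound 4 is estimated at 170 nM in this assay, most likely between 70 nM and 450 nM.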

Compound 4, half-maximal inhibitory concentration: 500 nM
Beside the measured number, compound 4's estimate is 2.9-fold (0.47 log units) below it; the whole stated range lies below it.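

In this assay, putting bromo in place of chloro on the core of compound 3 gives a 1.9-fold higher number from compound 3 to compound 4 (0.27 log units; within the scatter) and, taken alone, this is a small step. Set beside the same change on the core of compound 1, it does not match, and the mismatch is larger than repeat measurements would be expected to produce: the same change on two cores in this assay, a 1.8-fold lower number (0.25 log units; within the scatter) from compound 1 to compound 2 and a 1.9-fold higher number (0.27 log units; within the scatter) from compound 3 to compound 4, 3.3-fold (0.52 log units) apart, beyond the scatter of two such steps. Among these compounds, the size of the change on one core therefore cannot simply be carried over to the other, but with only one pair per core this shows that the two steps differ, not why they differ, and neither step alone goes beyond the scatter.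

The compounds shown carry only chloro or bromo at this place on the aromatic ring, so it remains open how fluoro, methyl, methoxy or an amine there would compare on either core. On these data alone, it also remains open whether the difference between the two cores would hold for any swap other than this one.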